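This account rests on a few compounds, and the source may have more. Where it says the series, first, only, none or still open, it means among the compounds named here.

Two compounds carrying the same core have so far been examined in an assay for inhibition of Thromboxane-A synthase (Homo sapiens), using microsomes; a higher number here means a weaker inhibitor, a lower number a stronger inhibitor. Compound 1 `O=C(O)CC/C=C\CC1COC(c2ccc(Cl)cc2Cl)OC1c1cccnc1` gives 42 nM in this assay, and compound 2 `Cc1ccc(C#N)c(OC(C)(C)C2OCC(C/C=C\CCC(=O)O)C(c3cccnc3)O2)c1` gives 50 nM. Of the two numbers, compound 2 carries the higher one, but the gap to compound 1 lies within the scatter, so the two cannot be told apart. Compound 3 `CC(C)(Oc1ccccc1O)C1OCC(C/C=C\CCC(=O)O)C(c2cccnc2)O1` has not yet been measured in this assay. It differs from compound 2 in one place: 2-hydroxyphenyl in place of 2-cyano-5-methylphenyl on an oxygen on a saturated carbon. Going by the values given here, no step between measured compounds is available to guide the size of this change, and the two numbers known sit close together. The expected step in this assay from compound 2 to compound 3 is therefore a 1.4-fold higher number from compound 2 to compound 3 (0.15 log units; within the scatter), nothing beyond the scatter. Compound 3 is estimated to give about 70 nM in this assay, with a range from 25 nM to 200 nM.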

Compound 3, half-maximal inhibitory concentration: 32 nM
For compound 3 the middle estimate is 2.2-fold (0.34 log units) above the measured one, within the range that was stated.
By their numbers in this assay, from the lowest: compounds 3, 1 and 2 (each within the scatter of the next).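

The exchange of 2-cyano-5-methylphenyl for 2-hydroxyphenyl on an oxygen on a saturated carbon gives a 1.6-fold lower number from compound 2 to compound 3 (0.19 log units; within the scatter) in this assay and so leaves compound 2 and compound 3 indistinguishable. The aromatic ring at this place can thus lose its nitrile and its methyl and carry a hydroxyl, adding a hydrogen-bond donor, with the number remaining inside the scatter. No independent data bear on why these two groups read alike.

Going by these compounds, the nitrile, the methyl and the hydroxyl all change in this single step, so what each contributes on its own remains open. Also open, on these data alone, is whether the same place accepts an unsubstituted phenyl, a 2-methoxyphenyl or an amine-bearing ring equally well.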